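Acylthiourea and acylurea benzimidazoles: a second chlorine on the benzyl ring

The source may report more compounds than this note shows. Statements on the series, on what has been measured and on what is new or still open speak of the compounds shown alone.

Working notes on three measured analogues and one to follow. In a functional assay on MGC-803 cells (Homo sapiens) for inhibition, read by MTT assay, with a stated time of 48 h (a higher number here means a weaker inhibitor, a lower number a stronger inhibitor), compound 3 `Cc1ccc(NC(=O)NC(=O)c2ccc(OCc3cccc(Cl)c3)cc2)cc1-c1nc2ccccc2[nH]1` gives 20800 nM, the second highest of the three numbers. Compound 1 `Cc1ccc(NC(=S)NC(=O)c2ccc(OCc3cccc(Cl)c3)cc2)cc1-c1nc2ccccc2[nH]1` gives 51300 nM, a higher number beyond the scatter. Compound 2 `O=C(NC(=S)Nc1ccc(Cl)c(-c2nc3ccccc3[nH]2)c1)c1ccc(OCc2ccc(Cl)c(Cl)c2)cc1` differs from compound 3 in several places. In this assay compound 2 gives 5170 nM, a lower number beyond the scatter. Compound 4 `Cc1ccc(NC(=O)NC(=O)c2ccc(OCc3cccc(Cl)c3Cl)cc2)cc1-c1nc2ccccc2[nH]1` is not yet measured; it differs from compound 3 by chloro in place of hydrogen on an aromatic carbon. Going by the values given here, no single-change step between measured compounds is available to anchor the size of this step. The step from compound 3 to compound 4 is expected to be a modest move toward a lower number, a 1.7-fold lower number from compound 3 to compound 4 (0.24 log units; within the scatter), close to the usual scatter. Compound 4 is therefore estimated at 12000 nM, with a range from 4000 nM to 35000 nM.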

Compound 4, half-maximal inhibitory concentration: > 100000 nM
Compound 4 gave a limit, no number (the forecaster's own chance of this, stated with the estimate: 5%); at least 8.3-fold (0.92 log units) between middle value and limit.
By their numbers in this assay, from the lowest: compound 2; then compound 3; then compound 1. At a limit, above all of these: compound 4.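

Going by these compounds alone, the change from 3-chlorobenzyl to 2,3-dichlorobenzyl gives the first single-change step, an at least 4.8-fold higher number from compound 3 to compound 4 (0.68 log units; beyond the scatter), so chloro at this place, ortho to a chloro group and ortho to a large group, weakens inhibition rather than strengthening it. In this assay compound 4 gives > 100000 nM, which is a limit and not a number. Only compound 4 sits at this limit: the limit of > 100000 nM in this assay, at which 1 of the 4 values shown sits.

On these data alone, the true size of the step stays unknown, as does its size in the acylthioureas. As far as these compounds go, whether a methoxy group or an amine at this place behaves as chloro does also remains open.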